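Furan-2-yl to phenyl on the saturated ring carbon

The source may report more compounds than this note shows. Statements on the series, on what has been measured and on what is new or still open speak of the compounds shown alone.

Of the two numbers measured in an assay on isolated protein for inhibition of glucose-6-phosphatase catalytic subunit 1 (Homo sapiens), read by inositol phosphate accumulation, with a stated time of 30 min, tested at 100 uM (a higher number here means more inhibition at the concentration tested (going by the name of the read-out), a lower number less inhibition), compound 2 `CC1(C)CC(=O)C2=C(C1)NC(c1ccccc1)=CC2c1ccco1` holds the upper one with 11.4%, while compound 1 `CC1(C)CC(=O)C2=C(C1)NC(c1ccccc1)=CC2c1ccc(F)cc1` gives 7.38%; the step of a number 4 percentage points higher from compound 1 to compound 2 (within the scatter) stays within the scatter. Compound 3 `CC1(C)CC(=O)C2=C(C1)NC(c1ccccc1)=CC2c1ccccc1` differs from compound 2 by phenyl in place of furan-2-yl on a saturated ring carbon. Within the data shown here, the only measured step bearing on this, furan-2-yl in place of 4-fluorophenyl on the same saturated ring carbon, did not move the number beyond the scatter, so the expected step is a number 2.4 percentage points lower from compound 2 to compound 3 (within the scatter), nothing beyond the scatter. Compound 3 is estimated at 9%, with a range from 0% to 20%.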

Compound 3, a percentage reported as inhibition, at one concentration (the size of the read-out at that concentration, not a potency): "not active" (no number reported)
Compound 3: no number reported; there is nothing to compare the estimate with.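

Among these compounds, compound 3 is reported as "not active" without a number, and no step from compound 2 to it can be read. Nothing shown bears on this result. The compounds shown leave open whether any group on the saturated ring carbon moves inhibition beyond the scatter.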